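Carboxy to tetrazole on the shared core: what to expect

The source may report more compounds than this note shows. Statements on the series, on what has been measured and on what is new or still open speak of the compounds shown alone.

Of the compounds shown here, two have been measured in a functional assay on the whole organism (strain Sprague-Dawley) for inhibition, with Rattus norvegicus as the target; a higher number here means that more compound is needed for the effect, a lower number that less compound is needed. Compound 1 `CCc1cccc2cc(C(=O)O)cnc12` gives 75 mg/kg in this assay, and compound 2 `COc1cccc2cc(C(=O)O)cnc12` gives 150 mg/kg. For the measured compounds named here, the single step between them, a 2.0-fold higher number from compound 1 to compound 2 (0.30 log units; within the scatter), comes from methoxy in place of ethyl on an aromatic carbon. On the numbers shown, compound 2 stands highest of the two, with compound 1 as its nearest neighbour, and that gap lies within the scatter.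

Compound 3 `COc1cccc2cc(-c3nn[nH]n3)cnc12` has not yet been measured. It differs from compound 2 as follows: 2H-tetrazol-5-yl in place of carboxy on an aromatic carbon. The carboxy leaves and the 2H-tetrazol-5-yl enters at the same aromatic carbon of the shared core.

Going by the values given here, no measured step concerns this kind of change or this position; the only step available sits elsewhere on the core and stayed within the scatter. These compounds therefore give no basis for expecting a shift in either direction beyond the scatter, and the uncertainty is wide. Compound 3 is estimated at 150 mg/kg, with a range from 50 mg/kg to 450 mg/kg. The step this estimate implies, no change at the digits printed from compound 2 to compound 3 (within the scatter), is expected to stay within the scatter.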

Compound 3, minimum effective dose: > 25 mg/kg
Compound 3: only a limit was reported; the forecaster's own chance of this, stated with the estimate: 20%; the middle value lies beyond the limit too.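

In this assay compound 3 gives > 25 mg/kg, which is a limit and not a number. The step from compound 2 to compound 3 therefore cannot be read. The compounds shown leave open whether 2H-tetrazol-5-yl in place of carboxy shifts the number in this assay beyond the scatter, and in which direction.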